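A few compounds are considered here, and "the series" means these few. Any claim that something is new, unique, unknown or untested is made for them only; others in the source may bear on it.

Of the compounds shown here, three built on one shared core have been tested in a functional assay on 786-0 cells (Homo sapiens) for inhibition, read by sulforhodamine B assay, with a stated time of 48 h, tested at 10 uM; a higher number here means more inhibition at the concentration tested (going by the name of the read-out), a lower number less inhibition. Compound 1 `Brc1cn2ccnc2c(-c2ccc3ncn(C4CCCCC4)c3c2)n1` gives 10%. Compound 2 `c1ccc(-c2cn3ccnc3c(-c3ccc4ncn(C5CCCCC5)c4c3)n2)cc1` gives 36.8%. Compound 3 `Brc1ccc(-c2cn3ccnc3c(-c3ccc4ncn(C5CCCCC5)c4c3)n2)cc1` gives 18%, the second highest of the three numbers; compound 1 sits nearest to it, within the scatter, while compound 2 lies beyond it. The steps spell this out: a number 8 percentage points higher from compound 1 to compound 3 (within the scatter), whereas a number 26.8 percentage points higher from compound 1 to compound 2 (beyond the scatter) and a number 18.8 percentage points lower from compound 2 to compound 3 (beyond the scatter).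

Compound 4 `c1csc(-c2cn3ccnc3c(-c3ccc4ncn(C5CCCCC5)c4c3)n2)c1` differs from compound 3 in one place: thiophen-2-yl in place of 4-bromophenyl on an aromatic carbon. The step of a number 18.8 percentage points lower from compound 2 to compound 3 (beyond the scatter) bears most directly on this change, since the group that leaves carries that same bromo; the step of a number 26.8 percentage points higher from compound 1 to compound 2 (beyond the scatter) shows the size of gain an unsubstituted aromatic ring brought. Within the data shown here, no measured compound carries thiophen-2-yl, so the expectation is held loosely. Because a number 18.8 percentage points lower from compound 2 to compound 3 (beyond the scatter) the loss of the bromo is expected to lift the number modestly in this assay. Compound 4 is therefore expected to give 28%, within the range 12% to 44%. That estimate corresponds to an expected step of a number 10 percentage points higher from compound 3 to compound 4 (within the scatter).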

Compound 4, a percentage reported as inhibition, at one concentration (the size of the read-out at that concentration, not a potency): 4.1%
Estimate against measurement, compound 4: 23.9 percentage points above; measured number outside the range, below it.
By their numbers in this assay, from the lowest: compounds 4, 1 and 3 (each within the scatter of the next, the first and the last beyond it); then compound 2.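

In this assay an aromatic ring at this position does not by itself lift the number: thiophen-2-yl in place of phenyl gives a number 32.7 percentage points lower from compound 2 to compound 4 (beyond the scatter) and so the earlier gain over bromo cannot be credited to just any aromatic ring placed here. Thiophen-2-yl in place of 4-bromophenyl gives a number 13.9 percentage points lower from compound 3 to compound 4 (beyond the scatter) and thiophen-2-yl in place of bromo gives a number 5.9 percentage points lower from compound 1 to compound 4 (within the scatter) so the five-membered ring brings no gain over bromo. Among these compounds, only the unsubstituted phenyl of compound 2 stands clear of compound 1.

Nothing measured here explains why thiophen-2-yl and phenyl differ so much at this position. Still open, going by these compounds, is whether a phenyl ring carrying a methoxy group or an amine, or a pyridine ring in its place, would keep the number of compound 2.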